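This account rests on a few compounds, and the source may have more. Where it says the series, first, only, none or still open, it means among the compounds named here.

Working notes on the series. Among the measured compounds shown here, the three compounds measured so far share a core and differ only in the substituent pattern on the aromatic ring attached to it. Compound 1, `Cc1ccccc1N1CCNC(=O)N1`, gives in an assay on RBL-1 cells for inhibition of Polyunsaturated fatty acid 5-lipoxygenase (Rattus norvegicus) (a higher number here means a weaker inhibitor, a lower number a stronger inhibitor), a value of 386000 nM. Compound 2, `Cc1cc(C)cc(N2CCNC(=O)N2)c1`, gives in this assay a value of 12000 nM. Compound 3, `O=C1NCCN(c2cccc(Cl)c2)N1`, gives in this assay a value of 5300 nM, the lowest of the three numbers; the gap to compound 2 lies beyond the scatter, as does the far larger gap to compound 1. No two of these compounds differ in a single place, so no single step between measured compounds can be read off.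

The next compound, compound 4, `O=C1NCCN(c2cccc([N+](=O)[O-])c2)N1`, has not yet been measured. It differs from compound 3 by nitro in place of chloro on an aromatic carbon. For the measured compounds named here, no measured pair isolates such an exchange, so the direction and size of the step rest on a judgment only. Compound 3 stands where it does with 5300 nM, and a change of comparable size is expected for compound 4 in this assay, with no strong reason for a large movement in either direction; a modest drift toward a higher number is expected, though it may fall within the scatter. The step from compound 3 to compound 4 is estimated as a 1.5-fold higher number from compound 3 to compound 4 (0.18 log units; within the scatter). Compound 4 is expected to give 8000 nM, within a range from 2500 nM to 25000 nM.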

Compound 4, half-maximal inhibitory concentration: 49000 nM
For compound 4 the middle estimate is 6.1-fold (0.79 log units) below the measured one; the whole stated range lies below it.
By their numbers in this assay, from the lowest: compound 3; then compound 2; then compound 4; then compound 1.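

In this assay, among the compounds shown here, nitro in place of chloro on this aromatic carbon gives a 9.2-fold higher number from compound 3 to compound 4 (0.97 log units; beyond the scatter), the first change that can be read at a single place. It shows that this position, meta to a group of 7 heavy atoms, is not indifferent to what it carries: with the rest of the structure held constant, exchanging chloro for nitro yields a clearly weaker inhibitor, so the two groups are not interchangeable here. Nothing on hand accounts for the size or direction of this step.

As far as these compounds go, this single pair cannot separate the contributions of what changes with the exchange, namely the three heavy atoms of nitro against the one of chloro and the two hydrogen-bond acceptors that enter, so it remains open whether any of these features goes with the loss or whether the result is specific to nitro. From the compounds shown here alone, how an amine, a nitrile or a carboxylic acid on this same aromatic carbon would compare with chloro and nitro also remains open, as does whether the same exchange would give a step of similar size elsewhere on the ring.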